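A few compounds are considered here, and "the series" means these few. Any claim that something is new, unique, unknown or untested is made for them only; others in the source may bear on it.

The measured compounds:
compound 1, `COc1ccc2nc(C)cc(SCc3ccc(F)cc3)c2c1`, 41000 nM
compound 2, `COc1ccc2nc(C)cc(SCc3ccccc3)c2c1`, 30600 nM
compound 3, `COc1cccc(CNc2cc(C)nc3ccc(OC)cc23)c1`, 9700 nM

All three were tested in a functional assay on MCF-10A cells (Homo sapiens) for antiproliferative activity, with a stated time of 48 h; on this read-out lower numbers stand for an effect already at smaller amounts and higher numbers for an effect only at larger amounts of compound. Compound 2 and compound 1 differ in one place only, (fluoro in place of hydrogen on an aromatic carbon), and that change gave a 1.3-fold higher number from compound 2 to compound 1 (0.13 log units; within the scatter). Compound 3 is built on a different core; how the core of compound 3 differs from that of compound 2 is not broken down here. In this assay compound 3 gives the lowest of the three numbers, and its steps to the other two lie beyond the scatter.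

Compound 4, `COc1ccc2nc(C)cc(NCc3ccc(F)c(OC)c3)c2c1`, is not yet measured. It arises from compound 3 by the same kind of change, (fluoro in place of hydrogen on an aromatic carbon). The surroundings are not identical: in compound 4 the fluoro enters ortho to a methoxy group and para to a large group, whereas in compound 1 it sits para to a large group only. Given that the earlier step of a 1.3-fold higher number from compound 2 to compound 1 (0.13 log units; within the scatter) stayed within the scatter, the step from compound 3 to compound 4 is expected to be of similar size, a 1.2-fold higher number from compound 3 to compound 4 (0.09 log units; within the scatter). Compound 4 is therefore estimated at 12000 nM, with a likely range from 5000 nM to 28000 nM.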

Compound 4, half-maximal effective concentration: 9500 nM
Compound 4: middle estimate off by 1.3-fold (0.10 log units), on the high side; the range from low to high includes it.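

In this assay, putting fluoro in place of hydrogen on an aromatic carbon gave a 1.0-fold lower number from compound 3 to compound 4 (0.01 log units; within the scatter). Set beside the earlier case, the same change gave matching results on the two cores: the same change on two cores in this assay, a 1.3-fold higher number (0.13 log units; within the scatter) from compound 2 to compound 1 and a 1.0-fold lower number (0.01 log units; within the scatter) from compound 3 to compound 4, 1.4-fold (0.14 log units) apart, within the scatter of two such steps. This shows that, for these two pairs, the swap left the number within the usual scatter on either core, but two pairs cannot show that it would do the same on a further core, and the surroundings also differ, since only in compound 4 does the fluoro sit ortho to a methoxy group.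

The compounds shown leave open whether a different group on the same aromatic carbon, such as chloro, trifluoromethyl, an amine or a carboxylic acid, would move the number beyond the scatter. They also leave open whether a longer chain joining the fluorinated ring to the shared core would change how the swap to fluoro behaves.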